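The source may report more compounds than this note shows. Statements on the series, on what has been measured and on what is new or still open speak of the compounds shown alone.

Compound 1 `CNC(=O)Cn1c(-c2ccc(Cl)cc2)nc2cccnc21`: 12.5 mg/kg in a functional assay on the whole organism with Mus musculus as the target; a higher number here means that more compound is needed for the effect, a lower number that less compound is needed
Compound 2 `CCN(CC)C(=O)Cn1c(-c2ccc(Cl)cc2)nc2cccnc21`: 16 mg/kg

Among these two measured compounds, compound 2 has the higher number in this assay, but the step of a 1.3-fold higher number from compound 1 to compound 2 (0.11 log units; within the scatter) lies within the usual scatter, so the two compounds cannot be told apart on this read-out. Compound 3 `O=C(Cn1c(-c2ccc(Cl)cc2)nc2cccnc21)N1CCCC1` has not yet been measured. It differs from compound 2 by pyrrolidin-1-yl in place of diethylamino on a carbonyl carbon. Among the compounds with values here, the only measured step at the same position, a 1.3-fold higher number from compound 1 to compound 2 (0.11 log units; within the scatter), was a small one, so compound 3 is expected to stay close to compound 2, with the step of no change at the digits printed from compound 2 to compound 3 (within the scatter) estimated to lie within the scatter. Compound 3 is therefore estimated at 16 mg/kg, likely between 8 mg/kg and 32 mg/kg.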

Compound 3, dose for half-maximal effect: 17.9 mg/kg
Compound 3: the middle estimate sits 1.1-fold (0.05 log units) below what was measured, and the stated range covers the measured number.
By their numbers in this assay, from the lowest: compounds 1, 2 and 3 (each within the scatter of the next).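

Putting a ring on the carbonyl carbon gives a number that cannot be told apart from the open diethylamino chain in this assay, with a 1.1-fold higher number from compound 2 to compound 3 (0.05 log units; within the scatter). The ring is also within the scatter of the small methylamino group, with a 1.4-fold higher number from compound 1 to compound 3 (0.16 log units; within the scatter), so these three amides read alike on this position. Nothing measured here offers an explanation for this.

Open, from the compounds shown here alone, is whether a piperidine or morpholine ring, or a chain carrying an amine or a carboxylic acid, would separate from these three. Going by these compounds, the chlorine on the shared core also remains untested by these compounds.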